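Chain extension of the amide across two cores

The source may hold more compounds than are shown below. What is called first, only, known or untested is meant among the compounds shown, and "the series" means these compounds.

Compound 1 `CCC(=O)NCc1ccc(OC)c(F)c1` and compound 2 `CCCC(=O)NCc1ccc(OC)c(F)c1` share one core; compound 3 `CCC(=O)NCc1ccc(F)c(OC)c1` carries the same atoms joined differently, and the difference between the two cores is not broken down here. Compound 4 `CCCC(=O)NCc1ccc(F)c(OC)c1` is the unmeasured partner of compound 3.

In an assay on isolated protein for agonist activity at melatonin receptor type 1C (Xenopus laevis), read by spectrophotometry (on this read-out lower numbers stand for an effect already at smaller amounts and higher numbers for an effect only at larger amounts of compound), compound 1 gives 1050 nM, compound 2 gives 661 nM and compound 3 gives 2880 nM. Against compound 3, compound 1 and compound 2 both give lower numbers with gaps beyond the scatter, compound 3 thus standing highest of the three.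

The change from compound 1 to compound 2 is methyl in place of hydrogen on a saturated chain carbon, two bonds along the chain from a carbonyl carbon, and the step was a 1.6-fold lower number from compound 1 to compound 2 (0.20 log units; within the scatter). The change from compound 3 to compound 4 is methyl in place of hydrogen on a saturated chain carbon, two bonds along the chain from a carbonyl carbon, the same change on the other core. Among the measured compounds shown here, since the only measured instance of this change, compound 1 to compound 2, produced a step inside the scatter, a 1.6-fold lower number from compound 1 to compound 2 (0.20 log units; within the scatter), compound 4 is expected to sit close to compound 3, with an expected step of a 1.5-fold lower number from compound 3 to compound 4 (0.18 log units; within the scatter). For compound 4 in this assay the estimate is 1900 nM, expected between 900 nM and 4000 nM.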

Compound 4, half-maximal effective concentration: 2510 nM
Compound 4: the middle estimate sits 1.3-fold (0.12 log units) below what was measured; measured number inside the range.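

In this assay, methyl in place of hydrogen on a saturated chain carbon, two bonds along the chain from a carbonyl carbon, gives a step within the scatter on the second core as well (a 1.1-fold lower number from compound 3 to compound 4 (0.06 log units; within the scatter)). On these two cores the change carries over as a step too small to read, and the two steps do not differ: the same change on two cores in this assay, a 1.6-fold lower number (0.20 log units; within the scatter) from compound 1 to compound 2 and a 1.1-fold lower number (0.06 log units; within the scatter) from compound 3 to compound 4, 1.4-fold (0.14 log units) apart, within the scatter of two such steps. Among the compounds shown here, this agreement shows only that neither core gives a step beyond the scatter; it does not show that the change truly lowers the number on either core, and two cores are no basis for a rule on any other core.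

As far as these compounds go, whether a longer chain or a branched chain on the carbonyl would move the number beyond the scatter stays open. Also open, from the compounds shown here alone, is what a chlorine or a nitrile in place of the fluorine would do on either core, and which part of the difference between the two cores matters.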